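Imidazole Methylation and Chlorination in a Dehydrogenase Inhibitor Series

The source may hold more compounds than are shown below. What is called first, only, known or untested is meant among the compounds shown, and "the series" means these compounds.

Compound 1 `CCCC[S+]([O-])c1sc2nc(-c3nccs3)cc(-c3ccc(C(C)(C)O)cc3)c2c1N`: 3.6 nM
Compound 2 `CCCC[S+]([O-])c1sc2nc(-c3nccs3)cc(-c3ccc(C(=O)OC)cc3)c2c1N`: 15.1 nM
Compound 3 `CCCC[S+]([O-])c1sc2nc(-c3nccs3)cc(-c3cnc(C)[nH]3)c2c1N`: 2.3 nM

Of the compounds shown here, three sharing one core have been measured in an assay for inhibition of 15-hydroxyprostaglandin dehydrogenase [NAD(+)] (Homo sapiens), read by fluorescence, with a stated time of 15 min, in the presence of a further agent that is not named here; a lower number here means a stronger inhibitor, a higher number a weaker inhibitor. Compound 3 gives the lowest of the three numbers, but its step to compound 1 is within the scatter: a 1.6-fold lower number from compound 1 to compound 3 (0.19 log units; within the scatter). Going by the values given here, only the step from compound 2 sets it apart: a 6.6-fold lower number from compound 2 to compound 3 (0.82 log units; beyond the scatter). The ester of compound 2 is the weakest of the three, as a 4.2-fold higher number from compound 1 to compound 2 (0.62 log units; beyond the scatter) also shows.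

Compound 4 `CCCC[S+]([O-])c1sc2nc(-c3nccs3)cc(-c3cnc(Cl)n3C)c2c1N` keeps the core and differs from compound 3 in one place: 2-chloro-1-methyl-1H-imidazol-5-yl in place of 2-methyl-1H-imidazol-5-yl on an aromatic carbon. Among the compounds with values here, none of the measured steps alters this same group; all three exchange the whole aromatic substituent at that position, and they show the position accepting differing groups with changes of modest size at most. Within the data shown here, with no direct precedent, the change from compound 3 to compound 4 is expected to be small, and compound 4 is estimated to give 5 nM in this assay, with a range of 1.5 nM to 20 nM, amounting to a 2.2-fold higher number from compound 3 to compound 4 (0.34 log units; beyond the scatter).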

Compound 4, half-maximal inhibitory concentration: 3.2 nM
For compound 4 the middle estimate is 1.6-fold (0.19 log units) above the measured one; measured number inside the range.
By their numbers in this assay, from the lowest: compounds 3, 4 and 1 (each within the scatter of the next); then compound 2.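

In this assay, the 2-chloro-1-methyl-1H-imidazol-5-yl group stays level with the 2-methyl-1H-imidazol-5-yl group (a 1.4-fold higher number from compound 3 to compound 4 (0.14 log units; within the scatter)), so at this position, opposite the ring nitrogen, an imidazole with no hydrogen-bond donor matches one that has a donor. The new group also stands level with the 4-(1-hydroxy-1-methylethyl)phenyl group (a 1.1-fold lower number from compound 1 to compound 4 (0.05 log units; within the scatter)) and clear of the 4-(methoxycarbonyl)phenyl group (a 4.7-fold lower number from compound 2 to compound 4 (0.67 log units; beyond the scatter)), which leaves the ester as the only one of the four set apart beyond the scatter. Nothing available bears on the reason for this result.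

The compounds shown do not separate the methyl on the imidazole nitrogen from the chlorine that replaces the carbon methyl. They also leave open whether an amine in place of that chlorine, or a longer chain on that nitrogen, would hold the same level.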